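The source may report more compounds than this note shows. Statements on the series, on what has been measured and on what is new or still open speak of the compounds shown alone.

Compound 1 `CNc1ncnc2c1c(-c1ccsc1)cn2[C@@H]1O[C@H](CO)[C@@H](O)[C@H]1O` carries a methylamino group and a thiophen-3-yl group on the shared core. In a functional assay on CCRF-CEM cells (Homo sapiens), read by MTT assay, with a stated time of 72 h (on this read-out lower numbers stand for stronger inhibition and higher numbers for weaker inhibition), compound 1 reaches only a limit, not a number, of > 20000 nM (the limit of > 20000 nM in this assay, at which 1 of the 2 values shown sits). Compound 2 `Cc1ncnc2c1c(-c1ccsc1)cn2[C@@H]1O[C@H](CO)[C@@H](O)[C@H]1O` has methyl in place of methylamino, and in this assay compound 2 gives 11200 nM. Among the measured compounds shown here, the only measured step, an at least 1.7-fold lower number from compound 1 to compound 2 (0.25 log units; that floor lies within the scatter), concerns that other position and not the thiophen-3-yl group. Compound 3 `CNc1ncnc2c1c(-c1ccco1)cn2[C@@H]1O[C@H](CO)[C@@H](O)[C@H]1O` brings the change (furan-2-yl in place of thiophen-3-yl on an aromatic carbon). For the measured compounds named here, no measured step bears on this exchange, so no shift beyond the scatter is expected. The expected step is a step that the limit leaves unreadable from compound 1 to compound 3. Compound 3 is therefore estimated at 30000 nM, between 8000 nM and 100000 nM.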

Compound 3, half-maximal inhibitory concentration: 180 nM
The estimate for compound 3 lay 170-fold (2.22 log units) above the measured number; measured number outside the range, below it.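

In this assay, among the compounds shown here, the group on this aromatic carbon proves decisive in a way the earlier compounds could not show: with methylamino held in place, furan-2-yl in place of thiophen-3-yl gives an at least 110-fold lower number from compound 1 to compound 3 (2.04 log units; beyond the scatter). This single exchange alters both the hetero atom and the point of attachment of the ring. Compound 1 stands at a limit and not at a number: the limit of > 20000 nM in this assay, at which 1 of the 3 values shown sits.

The compounds shown leave open which of those two differences carries the step, and how a thiophen-2-yl, furan-3-yl or phenyl group would read at this carbon. They also leave open whether furan-2-yl behaves alike with methyl in place of methylamino.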